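The compounds below may be only part of what the source reports. "The series", "measured", "known", "first", "only" and "open" are said of these compounds alone.

Measured in a functional assay on HEL cells (Homo sapiens); a lower number here means that less compound is tolerated, a higher number that more compound is tolerated:
- compound 1 `CCCCc1cc2cn(COCCO)c(=O)nc2o1`: > 200000 nM
- compound 2 `CCCCCCCC#Cc1cc2cn(COCCO)c(=O)nc2o1`: > 50000 nM
- compound 3 `CCCCCc1cc2cn(COCCO)c(=O)nc2o1`: > 200000 nM

None of these three results is a true number. Compound 3 stands only at a limit, > 200000 nM. Compound 1 has the same limit, > 200000 nM. Compound 2 also stands at a limit, > 50000 nM.

The step to follow leads to compound 4 `CCCCCC#Cc1cc2cn(COCCO)c(=O)nc2o1`. The difference is hept-1-yn-1-yl in place of pentyl on an aromatic carbon, which in words is hept-1-yn-1-yl in place of pentyl on an aromatic carbon.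

Going by the values given here, the one measured step that bears on this change is a step that the two limits leave unreadable from compound 1 to compound 3, with methyl in place of hydrogen on a saturated chain carbon. It offers no size and no direction to carry over. Among the compounds with values here, compound 2 is the only measured compound that also has a triple bond outside aromatic rings, and its result is the limit > 50000 nM.

Nothing measured therefore points to a change beyond the scatter in this assay, and none is expected. The expected size of the change is an at least 2.0-fold lower number from compound 3 to compound 4 (0.30 log units; that floor lies within the scatter). Compound 4 is likely to be reported as a limit as well. The estimate for compound 4 is 100000 nM, with an expected range from 40000 nM to 200000 nM.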

Compound 4, half-maximal cytotoxic concentration: > 50000 nM
Compound 4 was reported as a limit; the forecaster's own chance of this, stated with the estimate: 85%; the middle value is on the limit's open side.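

In this assay compound 4 gives > 50000 nM, which is a limit and not a number. The steps from compound 1, compound 2 and compound 3 to compound 4 cannot be read, as all four values are limits. The compounds shown leave open at what concentration any of them is cytotoxic, and whether changing the chain on the shared core alters that concentration.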